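This account rests on a few compounds, and the source may have more. Where it says the series, first, only, none or still open, it means among the compounds named here.

Measured so far:
compound 1 `CNC(=O)c1cc(Oc2ccc3nc(NC(=O)c4ccc(Cl)cc4Cl)sc3c2)ccn1` gives 15.1%
compound 2 `CNC(=O)c1cc(Oc2ccc3nc(NC(=O)Nc4ccc(N5CCN(C)CC5)cc4)sc3c2)ccn1` gives 24.6%
compound 3 `CNC(=O)c1cc(Oc2ccc3nc(NC(=O)Nc4ccc(Cl)cc4)sc3c2)ccn1` gives 57.4%

In a functional assay on HCT-116 cells (Homo sapiens) for inhibition, read by MTT assay, with a stated time of 2 days, tested at 10 uM (on this read-out lower numbers stand for less inhibition of growth and higher numbers for more inhibition of growth at the one concentration tested), compound 1 stands lowest of the three, with compound 2 within the scatter of it and compound 3 well beyond. The step to compound 4 `CNC(=O)c1cc(Oc2ccc3nc(NC(=O)c4cccc(F)n4)sc3c2)ccn1` is 6-fluoropyridin-2-yl in place of 2,4-dichlorophenyl on a carbonyl carbon; the amide itself stays. Of the measured steps, only a number 42.3 percentage points higher from compound 1 to compound 3 (beyond the scatter) touches the same carbonyl carbon, yet it also turns the amide into a urea, so it is at best a distant guide; a number 32.8 percentage points higher from compound 2 to compound 3 (beyond the scatter) concerns the urea series and does not bear on it. Within the data shown here, no measured step swaps one aryl amide for another. Compound 4 is therefore expected to stay close to compound 1, with a number 6.9 percentage points higher from compound 1 to compound 4 (within the scatter), and an estimate of 22% (range 5% to 50%).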

Compound 4, percent growth inhibition at one concentration: 10.8%
For compound 4 the middle estimate is 11.2 percentage points above the measured one; low and high end bracket the measured number.
By their numbers in this assay, from the lowest: compounds 4, 1 and 2 (each within the scatter of the next, the first and the last beyond it); then compound 3.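

In this assay, among these compounds, the first swap of one aromatic group for another on this carbonyl carbon gives a number 4.3 percentage points lower from compound 1 to compound 4 (within the scatter), so 6-fluoropyridin-2-yl and 2,4-dichlorophenyl cannot be told apart at this position. Set against the urea, the same group gives a number 46.6 percentage points lower from compound 3 to compound 4 (beyond the scatter), which places compound 4 with compound 1, well apart from compound 3. No evidence at hand accounts for either step.

From the compounds shown here alone, it remains open whether the large gap belongs to the urea linkage or to the aromatic group it carries. Going by these compounds, how a 4-chlorophenyl or a morpholin-4-yl group would read directly on this carbonyl carbon also remains open.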